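This account rests on a few compounds, and the source may have more. Where it says the series, first, only, none or still open, it means among the compounds named here.

Compound 1 `O=C1c2cc(COc3ccccc3)nn2CCN1c1ccc(F)cc1` is the starting point of this small set. In a functional assay on HEK293 cells for positive allosteric modulation of metabotropic glutamate receptor 5 (Homo sapiens), read by calcium flux (on this read-out higher numbers stand for larger maximal responses and lower numbers for smaller maximal responses), compound 1 gives 79%. Compound 2 `O=C1c2cc(COc3ccccc3)nn2CCN1c1ccccn1` carries pyridin-2-yl where compound 1 carries 4-fluorophenyl; in this assay compound 2 gives 69%, and the two values differ by a number 10 percentage points lower from compound 1 to compound 2 (within the scatter). Compound 3 `Cc1ccc(N2CCn3nc(COc4ccccc4)cc3C2=O)nc1` is the 5-methylpyridin-2-yl analogue; in this assay compound 3 gives 76%, a step of a number 3 percentage points lower from compound 1 to compound 3 (within the scatter). Within the set compound 1 stands highest, but both gaps lie within the scatter, so no ordering is claimed.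

The unmeasured compound 4 `Cc1c(COc2ccccc2)nn2c1C(=O)N(c1ccc(F)cc1)CC2` arises from compound 1 by methyl in place of hydrogen on an aromatic carbon. The same kind of change occurs once among the measured pair, from compound 2 to compound 3: methyl in place of hydrogen on an aromatic carbon. There it made a step of a number 7 percentage points higher from compound 2 to compound 3 (within the scatter), which is within the scatter. The two places are not the same: in compound 3 the methyl sits on a six-membered aromatic ring with one nitrogen, para to a large group, while in compound 4 it sits on a five-membered aromatic ring with two nitrogen, part of a fused system, next to the ring atom bearing the phenoxymethyl group. The cores also differ, by 4-fluorophenyl in place of pyridin-2-yl on an amide-type nitrogen in a ring, so the earlier step is only a loose guide.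

Given that the one comparable step, from compound 2 to compound 3, stayed within the scatter, compound 4 is expected to change from compound 1 by about a number 1 percentage points higher from compound 1 to compound 4 (within the scatter). The maximal response of compound 4 in this assay is estimated at 80%, likely between 64% and 96%.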

Compound 4, largest response reached (Emax), in percent of the reference or control that the assay uses: 32%
Compound 4: middle estimate off by 48 percentage points, on the high side, outside the stated range (below it).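

On the five-membered aromatic ring with 2 nitrogen, methyl in place of hydrogen on an aromatic carbon gives a step of a number 47 percentage points lower from compound 1 to compound 4 (beyond the scatter) in this assay. This result shows that, within these compounds, a step seen for this change on one core cannot be carried over to another, and each case has to be read on its own core: the same change on two cores in this assay, a number 7 percentage points higher (within the scatter) from compound 2 to compound 3 and a number 47 percentage points lower (beyond the scatter) from compound 1 to compound 4, 54 percentage points apart, beyond the scatter of two such steps It does not show what separates the two cases, since they differ both in the ring that carries the methyl and in the group on the amide-type nitrogen, and a single pair for each case cannot tell these two differences apart or support a general rule for the series.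

On these data alone, it remains open whether the lower maximal response belongs to methyl specifically or would also appear with another group on the same carbon, such as ethyl, a chlorine atom or a methoxy group. As far as these compounds go, it is also open how methyl on the five-membered ring behaves when pyridin-2-yl or 5-methylpyridin-2-yl, rather than 4-fluorophenyl, sits on the amide-type nitrogen.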